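Swapping the whole aryl group of compound 2

The compounds below may be only part of what the source reports. "The series", "measured", "known", "first", "only" and "open" are said of these compounds alone.

Measured in a physicochemical assay for permeability, using PAMPA; on this read-out higher numbers stand for higher permeability and lower numbers for lower permeability:
Compound 1 `Cc1oc(-c2c(Br)cccc2Br)nc1CN1CCC(C(=O)NCCCN2C[C@H](C)C[C@H](C)C2)CC1`: < 1 10^-6 cm/s (a limit)
Compound 2 `COc1cccc(Br)c1-c1nc(CN2CCC(C(=O)NCCCN3C[C@H](C)C[C@H](C)C3)CC2)c(C)o1`: 245 10^-6 cm/s

Compound 1 gives < 1 10^-6 cm/s, which is a limit of the assay and not a number. Among the measured compounds shown here, compound 2, at 245 10^-6 cm/s, therefore holds the only true number so far.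

Compound 3 `Cc1ccc(-c2nc(CN3CCC(C(=O)NCCCN4C[C@H](C)C[C@H](C)C4)CC3)c(C)o2)cc1C` keeps the shared core but carries 3,4-dimethylphenyl in place of 2-bromo-6-methoxyphenyl on an aromatic carbon. For the measured compounds named here, one measured step bears on this, an at least 240-fold higher number from compound 1 to compound 2 (2.38 log units; beyond the scatter). It is large and lies within the group that now leaves, so changes there can matter greatly in this assay. It cannot fix the direction, since the entering group has neither bromo nor methoxy. With compound 2 at 245 10^-6 cm/s, a fall seems likelier than a further rise, though the uncertainty is wide.

The expected step is a 4.1-fold lower number from compound 2 to compound 3 (0.61 log units; beyond the scatter).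

For compound 3 the estimate is 60 10^-6 cm/s, with an expected range from 5 10^-6 cm/s to 300 10^-6 cm/s.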

Compound 3, apparent permeability: 219 10^-6 cm/s
Compound 3: the middle estimate sits 3.7-fold (0.56 log units) below what was measured; the measured number falls inside the stated range.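

In this assay, exchanging the whole aryl group gives a 1.1-fold lower number from compound 2 to compound 3 (0.05 log units; within the scatter), so a high number here needs neither the methoxy nor the bromo of 2-bromo-6-methoxyphenyl, and 3,4-dimethylphenyl, which carries neither, serves as well. The other new step, an at least 210-fold higher number from compound 1 to compound 3 (2.34 log units; beyond the scatter), gives a second route to the same contrast: among the three aryl groups shown, 2,6-dibromophenyl alone stands apart, while the other two cannot be told apart in this assay. Compound 1 gives only a limit and not a number, so the true size of that step stays unknown: the limit of < 1 10^-6 cm/s in this assay, at which 1 of the 3 values shown sits.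

From the compounds shown here alone, whether other aryl groups would also stay high or would fall as far as compound 1 remains open. How this position would respond to an amine or a carboxylic acid on the phenyl ring is open too.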